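The source may report more compounds than this note shows. Statements on the series, on what has been measured and on what is new or still open speak of the compounds shown alone.

Compound 1 `C=CC[C@H]1C[C@]2([C@@H](C)Cc3ccc(OC)c(OC)c3)OCOC2=CC1=O` is the reference point of this set. In a functional assay on M14 cells (Homo sapiens) for antiproliferative activity, with a stated time of 72 h (a lower number here means a stronger inhibitor, a higher number a weaker inhibitor), compound 1 gives 110 nM, the second highest of the three numbers recorded. Compound 3 `C=CC[C@H]1C[C@]2([C@@H](C)Cc3ccc(OC)c(C#N)c3)OCOC2=CC1=O` gives 180 nM, and compound 2 `C=CC[C@H]1C[C@]2([C@@H](C)Cc3ccc(OC)c(C(N)=O)c3)OCOC2=CC1=O` gives 12 nM. The step of a 1.6-fold higher number from compound 1 to compound 3 (0.21 log units; within the scatter) stays within the scatter, whereas a 9.2-fold lower number from compound 1 to compound 2 (0.96 log units; beyond the scatter) and a 15-fold higher number from compound 2 to compound 3 (1.18 log units; beyond the scatter) lie beyond it.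

Compound 4 `C=CC[C@H]1C[C@]2([C@@H](C)Cc3cc(OC)c(OC)cc3F)OCOC2=CC1=O` differs from compound 1 by fluoro in place of hydrogen on an aromatic carbon. Among the compounds with values here, all three measured steps concern the exchange of the methoxy, carbamoyl and cyano groups on the aromatic ring; none of them puts a fluoro in place of a hydrogen anywhere, so no measured step bears on this change, and its size cannot be read from the numbers at hand. For compound 4 the step expected is no change at the digits printed from compound 1 to compound 4 (within the scatter), that is, nothing beyond the scatter in either direction. Compound 4 is estimated at 110 nM in this assay, with a range from 40 nM to 320 nM.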

Compound 4, half-maximal inhibitory concentration: 14 nM
Estimate against measurement, compound 4: 7.9-fold (0.90 log units) above; measured number outside the range, below it.
By their numbers in this assay, from the lowest: compounds 2 and 4 (each within the scatter of the next); then compounds 1 and 3 (each within the scatter of the next).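

In this assay, a 7.9-fold lower number from compound 1 to compound 4 (0.90 log units; beyond the scatter), so a single fluoro on an aromatic carbon, ortho to a large group and with both methoxy groups kept, moves the number beyond the scatter. The earlier steps shown here exchanged only the methoxy, carbamoyl and cyano groups at one ring carbon, whereas this step shows that a carbon bearing hydrogen in compound 1 also responds to substitution, and that the gain does not require replacing a methoxy group. No measurement given here accounts for this step.

As far as these compounds go, whether chloro, methyl or an amine on the same carbon would give a similar step remains open. Also open, from the compounds shown here alone, is whether this fluoro and the carbamoyl of compound 2 would add up when placed together on the shared core.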